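Moving the Chlorine Around the Benzyl Ring: Expected Cytotoxicity

This account rests on a few compounds, and the source may have more. Where it says the series, first, only, none or still open, it means among the compounds named here.

Three compounds share one core and differ only in the ring attached to the sulfur-bound chain carbon. In an ADME assay on HaCaT cells (Homo sapiens) for cytotoxicity, read by MTT assay, with a stated time of 72 h (a lower number here means a stronger inhibitor, a higher number a weaker inhibitor), compound 1 `C/C(C#Cc1ccccc1)=N\N/C(N)=N/S(=O)(=O)c1cc(C)c(Cl)cc1SCc1ccc(C)cc1` gives 270000 nM, compound 2 `C/C(C#Cc1ccccc1)=N\N/C(N)=N/S(=O)(=O)c1cc(C)c(Cl)cc1SCc1ccccc1C(F)(F)F` gives 18000 nM, and compound 3 `C/C(C#Cc1ccccc1)=N\N/C(N)=N/S(=O)(=O)c1cc(C)c(Cl)cc1SCc1ccccc1Cl` gives 340000 nM. Compound 3 has the highest number of the three: a 1.3-fold higher number from compound 1 to compound 3 (0.10 log units; within the scatter), whereas a 19-fold higher number from compound 2 to compound 3 (1.28 log units; beyond the scatter). Compound 4 `C/C(C#Cc1ccccc1)=N\N/C(N)=N/S(=O)(=O)c1cc(C)c(Cl)cc1SCc1cccc(Cl)c1` differs from compound 3 only in that (3-chlorophenyl in place of 2-chlorophenyl on a saturated chain carbon bound to a sulfur). Among the compounds with values here, no measured step moves a chloro group from one ring position to another; the one step touching this ring, a 1.3-fold higher number from compound 1 to compound 3 (0.10 log units; within the scatter), stayed within the scatter, so no step beyond the scatter is expected in this assay. Compound 4 is therefore estimated at 300000 nM, within 100000 nM to 900000 nM. The expected step is a 1.1-fold lower number from compound 3 to compound 4 (0.05 log units; within the scatter).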

Compound 4, half-maximal inhibitory concentration: 155000 nM
Compound 4: the middle estimate sits 1.9-fold (0.29 log units) above what was measured; low and high end bracket the measured number.
By their numbers in this assay, from the lowest: compound 2; then compounds 4, 1 and 3 (each within the scatter of the next, the first and the last beyond it).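

Moving the chlorine from 2-chlorophenyl to 3-chlorophenyl gives a 2.2-fold lower number from compound 3 to compound 4 (0.34 log units; beyond the scatter) in this assay, so on this ring the place of the chlorine can shift the number, which no earlier step could show. The move still leaves a wide gap to the trifluoromethyl compound, with an 8.6-fold higher number from compound 2 to compound 4 (0.94 log units; beyond the scatter), while the comparison with the methyl compound gives a 1.7-fold lower number from compound 1 to compound 4 (0.24 log units; within the scatter) and shows no clear difference. Nothing available explains why the position matters. Still open, on these data alone, is whether an amine or a carboxylic acid in place of the chlorine would give a different number.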